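The source may report more compounds than this note shows. Statements on the series, on what has been measured and on what is new or still open speak of the compounds shown alone.

Measured so far in a functional assay on NALM-6 cells (Homo sapiens) for cytotoxicity, read by luminescence and CellTiter-Glo, with a stated time of 3 days; on this read-out higher numbers stand for weaker inhibition and lower numbers for stronger inhibition:

compound 1 `O=C(Nc1cc(C(F)(F)F)cc(C(F)(F)F)c1)c1ccc(Br)cc1O` at 1200 nM
compound 2 `O=C(Nc1cc(C(F)(F)F)cc(C(F)(F)F)c1)c1ccc(-c2ccccc2)cc1O` at 1580 nM

Compound 1 has a single measured neighbour, and the two cannot be separated. The step is a 1.3-fold higher number from compound 1 to compound 2 (0.12 log units; within the scatter) with phenyl in place of bromo on an aromatic carbon.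

Next is compound 3 `O=C(Nc1cc(C(F)(F)F)cc(C(F)(F)F)c1)c1cc(Br)ccc1O`, which has the same atoms as compound 1, joined differently. The change is 5-bromo-2-hydroxyphenyl in place of 4-bromo-2-hydroxyphenyl on a carbonyl carbon and the rest of the structure stays as it is: 5-bromo-2-hydroxyphenyl in place of 4-bromo-2-hydroxyphenyl on a carbonyl carbon.

For the measured compounds named here, no measured step tests this change directly. The step to compound 2 is the only one available, and it bears on the question loosely, since it replaces the bromo and does not show what 5-bromo-2-hydroxyphenyl does. On these data alone, with that single step inside the scatter, no step beyond the scatter is expected in this assay and the direction remains open, so the range is kept wide.

The estimate corresponds to an expected 1.3-fold lower number from compound 1 to compound 3 (0.12 log units; within the scatter) and should be read with that range in mind. Compound 3 is estimated at 900 nM with a range from 300 nM to 2500 nM expected for a single measurement.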

Compound 3, half-maximal inhibitory concentration: 590 nM
For compound 3 the middle estimate is 1.5-fold (0.18 log units) above the measured one, and the stated range covers the measured number.
By their numbers in this assay, from the lowest: compound 3; then compounds 1 and 2 (each within the scatter of the next).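

In this assay, for the compounds shown here, the exchange of 4-bromo-2-hydroxyphenyl for 5-bromo-2-hydroxyphenyl on the carbonyl carbon gives the first step beyond the scatter: a 2.0-fold lower number from compound 1 to compound 3 (0.31 log units; beyond the scatter), a modest step. The earlier step, a 1.3-fold higher number from compound 1 to compound 2 (0.12 log units; within the scatter), replaced the bromo with phenyl and stayed within the scatter, so it gave no sign that this part of the molecule affects the read-out; the new pair shows that the arrangement of the same atoms can shift the number, with the heavy-atom count and the counted donors and acceptors unchanged. Nothing available accounts for this difference between compound 1 and compound 3.

The compounds shown leave open whether the gain with 5-bromo-2-hydroxyphenyl is specific to bromo or would persist with chloro, methoxy, an amine or a carboxylic acid in that group. They also leave open whether the hydroxy group is needed, for example whether a methoxy group in its place would keep the number seen for compound 3, and whether phenyl in place of the bromo of compound 3 would behave as it did from compound 1.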